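A few compounds are considered here, and "the series" means these few. Any claim that something is new, unique, unknown or untested is made for them only; others in the source may bear on it.

Measured so far in a functional assay on HL-60 cells (Homo sapiens) for antiproliferative activity, read by MTT assay (a higher number here means a weaker inhibitor, a lower number a stronger inhibitor), are three compounds:
- compound 1 `CNC1=CC(=O)c2ccccc2C1=O` at 41400 nM
- compound 2 `O=C1C=C(NCCO)C(=O)c2ccccc21` at 49800 nM
- compound 3 `NCCCNC1=CC(=O)c2ccccc2C1=O` at 30000 nM

Compound 3 does not stand apart from the other two. The measured steps are a 1.4-fold lower number from compound 1 to compound 3 (0.14 log units; within the scatter) and a 1.7-fold lower number from compound 2 to compound 3 (0.22 log units; within the scatter) and also a 1.2-fold higher number from compound 1 to compound 2 (0.08 log units; within the scatter) in this series.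

Compound 4 `O=C1C=C(NCc2ccccc2)C(=O)c2ccccc21` differs from compound 3 by phenyl in place of 2-aminoethyl on a saturated chain carbon bound to an amine nitrogen and so carries phenyl in place of 2-aminoethyl on a saturated chain carbon bound to an amine nitrogen. All three steps change the same chain, but none brings in a ring, so they bear on this change only loosely. No step beyond the scatter is expected in this assay and no firm direction can be given. The expected step is a 1.2-fold lower number from compound 3 to compound 4 (0.08 log units; within the scatter) by this estimate. For compound 4 the estimated value is 25000 nM with an expected range from 8000 nM to 60000 nM allowing for the untested ring.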

Compound 4, half-maximal inhibitory concentration: 86500 nM
Compound 4: middle estimate off by 3.5-fold (0.54 log units), on the low side; the measured number lies above the stated range.
By their numbers in this assay, from the lowest: compounds 3, 1, 2 and 4 (each within the scatter of the next, the first and the last beyond it).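

Phenyl on the saturated chain carbon bound to an amine nitrogen brings the first steps beyond the scatter in this assay: a 2.9-fold higher number from compound 3 to compound 4 (0.46 log units; beyond the scatter) in place of 2-aminoethyl and a 2.1-fold higher number from compound 1 to compound 4 (0.32 log units; beyond the scatter) in place of hydrogen, both modest. In place of hydroxymethyl the same ring gives a 1.7-fold higher number from compound 2 to compound 4 (0.24 log units; within the scatter) and so does not separate the two compounds. No evidence on hand bears on these steps.

Open, from the compounds shown here alone, is whether a pyridine ring in place of phenyl gives the same step. Also open, going by these compounds, is whether a longer chain carrying phenyl does.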